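Replacing the Pyridinyl Group of Compound 2

This account rests on a few compounds, and the source may have more. Where it says the series, first, only, none or still open, it means among the compounds named here.

Measured in a physicochemical assay for lipophilicity, using the shake flask method, in phosphate buffer, measured as octanol-water partition, with a stated time of 30 min, at pH 7.4; a lower number here means a more polar compound, a higher number a more lipophilic compound
- compound 1 `O=C1c2ccccc2CN1c1cnc(NCc2c(F)ccc3c2CCO3)n2cnnc12` gives 2.7
- compound 2 `Cc1nc(CN(C)C)ccc1-c1cnc(NCc2c(F)ccc3c2CCO3)c2cn[nH]c(=O)c12` gives 2
- compound 3 `CN(c1cccnc1)c1cnc(NCc2c(F)ccc3c2CCO3)n2cnnc12` gives 2.6

Compound 2 stands lowest of these three, beyond the scatter from both compound 1 and compound 3. Compound 4 `CN(c1ccn(C)n1)c1cnc(NCc2c(F)ccc3c2CCO3)c2cn[nH]c(=O)c12` keeps the core of compound 2 and exchanges one group on an aromatic carbon: 6-((dimethylamino)methyl)-2-methylpyridin-3-yl leaves and methyl(1-methyl-1H-pyrazol-3-yl)amino enters methyl(1-methyl-1H-pyrazol-3-yl)amino in place of 6-((dimethylamino)methyl)-2-methylpyridin-3-yl on an aromatic carbon in its place.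

One measured step offers a comparison: a number 0.10 log units lower from compound 1 to compound 3 (within the scatter) also exchanges one ring-bearing group for another on an aromatic carbon. That step sits on a different core from compound 2, so it is only a loose guide. The data cannot show how much of the gap between compound 2 and compound 3 (2.6) comes from the core and how much from the group. A modest rise in this assay is therefore expected, covering part of that gap. The expected move is a number 0.40 log units higher from compound 2 to compound 4 (beyond the scatter) and it remains uncertain. For compound 4 the estimated value is 2.4 (range 1.9 to 2.9).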

Compound 4, distribution coefficient: 2.4
Compound 4: middle estimate and measured number agree at the digits printed; low and high end bracket the measured number.
By their numbers in this assay, from the lowest: compound 2; then compounds 4, 3 and 1 (each within the scatter of the next).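

In this assay the core of compound 2 is kept, and putting methyl(1-methyl-1H-pyrazol-3-yl)amino in place of 6-((dimethylamino)methyl)-2-methylpyridin-3-yl gives a number 0.40 log units higher from compound 2 to compound 4 (beyond the scatter) on this core. This is the first step shown at this position, and it shows that the group on this aromatic carbon can move the number beyond the scatter. The exchange alters several features together, including the ring size and the dimethylamino side chain, and nothing shown gives a measured reason for the shift.

The compounds shown do not separate the contributions of the ring, the side chain and the linking nitrogen to this step. On these data alone, how an amine such as morpholine or a carboxylic acid at this position would read on this core also remains open.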